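Notes on a carbonyl aryl exchange carried across two cores

The source may report more compounds than this note shows. Statements on the series, on what has been measured and on what is new or still open speak of the compounds shown alone.

Compound 1 `Cc1ccc(C(=O)Nc2sc3c(c2C(N)=O)CCN(C(=S)Nc2ccccc2Cl)C3)cc1` and compound 2 `NC(=O)c1c(NC(=O)c2cccc([N+](=O)[O-])c2)sc2c1CCN(C(=S)Nc1ccccc1Cl)C2` share one core; compound 3 `Cc1ccc(C(=O)Nc2sc3c(c2C(N)=O)CCN(C(=S)Nc2cc(C(F)(F)F)cc(C(F)(F)F)c2)C3)cc1` and compound 4 `NC(=O)c1c(NC(=O)c2cccc([N+](=O)[O-])c2)sc2c1CCN(C(=S)Nc1cc(C(F)(F)F)cc(C(F)(F)F)c1)C2` share another. The difference between the two cores is not broken down here.

In a functional assay on MKN-74 cells (Homo sapiens) for antiproliferative activity, with a stated time of 24 h (on this read-out higher numbers stand for weaker inhibition and lower numbers for stronger inhibition), compound 1 gives 11300 nM. Compound 2 carries 3-nitrophenyl in place of 4-methylphenyl on a carbonyl carbon, and in this assay compound 2 gives 8850 nM, which amounts to a 1.3-fold lower number from compound 1 to compound 2 (0.11 log units; within the scatter). In this assay compound 3 gives 14900 nM. All three numbers lie within the scatter of one another, so no order among the measured compounds is claimed.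

Compound 4 differs from compound 3 by 3-nitrophenyl in place of 4-methylphenyl on a carbonyl carbon. In both pairs the change sits on a carbonyl carbon whose other neighbours are an amide-type nitrogen, so this is the same change, now made on the second core. It has been seen only once among measured compounds, where it produced a 1.3-fold lower number from compound 1 to compound 2 (0.11 log units; within the scatter), a step that stays within the scatter. Going by the values given here, whether the second core alters the outcome cannot be read from the data, since no measured pair shows it.

Among the compounds with values here, the expectation for compound 4 is therefore a number close to that of compound 3, with an estimated step of a 1.3-fold lower number from compound 3 to compound 4 (0.11 log units; within the scatter), resting on the single measured instance a 1.3-fold lower number from compound 1 to compound 2 (0.11 log units; within the scatter). In this assay compound 4 is estimated at 11500 nM, expected to fall between 6000 nM and 22000 nM.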

Compound 4, half-maximal inhibitory concentration: 25800 nM
Compound 4: middle estimate off by 2.2-fold (0.35 log units), on the low side, outside the stated range (above it).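

In this assay, the exchange of 4-methylphenyl for 3-nitrophenyl on the carbonyl carbon, carried onto the second core, gives a 1.7-fold higher number from compound 3 to compound 4 (0.24 log units; within the scatter), so this pair is not separated by the measurement. Set beside the step on the first core, the new step does not differ from it beyond the scatter: the same change on two cores in this assay, a 1.3-fold lower number (0.11 log units; within the scatter) from compound 1 to compound 2 and a 1.7-fold higher number (0.24 log units; within the scatter) from compound 3 to compound 4, 2.2-fold (0.34 log units) apart, within the scatter of two such steps. This shows that the exchange has produced no step beyond the scatter on either core and that the two cores give no measurable sign of a different outcome, but it does not show that the exchange transfers reliably from core to core, since two pairs whose steps all lie within the scatter cannot establish either a shared effect or a dependence on the core, and nothing here extends past compound 1, compound 2, compound 3 and compound 4.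

Still open, from the compounds shown here alone, is whether any group on this carbonyl carbon can produce a step beyond the scatter on both cores, for example a phenyl ring carrying an amine or a carboxylic acid, or a saturated cyclohexyl group in place of the aromatic ring. A larger set of such pairs on both cores would also be needed to tell whether the outcome of an exchange at this place depends on the core at all.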